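Compound 1 to compound 3: loss of the glycosyl group

This account rests on a few compounds, and the source may have more. Where it says the series, first, only, none or still open, it means among the compounds named here.

Measured in a functional assay on K562 cells (Homo sapiens) for cytotoxicity, read by spectrophotometry; a higher number here means a weaker inhibitor, a lower number a stronger inhibitor:
compound 1 `CC(=O)O[C@@H](C[C@@H]1C(C)=CCC(=O)C1(C)C)/C(C)=C/[C@@H](C/C=C(\C)CC[C@H]1C(C)(C)[C@@H](O[C@@H]2O[C@H](CO)[C@H](O)[C@H](O)[C@H]2O)CC[C@]1(C)OC(C)=O)OC(C)=O` gives 17000 nM here
compound 2 `CC(=O)O[C@H]1[C@H](O[C@H]2CC[C@](C)(OC(C)=O)[C@@H](CC/C(C)=C/C[C@H](/C=C(\C)[C@H](C[C@@H]3C(C)=CCC(=O)C3(C)C)OC(C)=O)OC(C)=O)C2(C)C)O[C@H](CO)[C@H](O)[C@@H]1O` gives 12500 nM here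

Compound 1 has only one measured partner, and the two values lie within the scatter of each other, so neither stands apart in this assay on these numbers.

Still unmeasured is compound 3 `CC(=O)O[C@@H](C[C@@H]1C(C)=CCC(=O)C1(C)C)/C(C)=C/[C@@H](C/C=C(\C)CC[C@H]1C(C)(C)[C@@H](O)CC[C@]1(C)OC(C)=O)OC(C)=O`. Its difference from compound 1 is hydrogen in place of 3,4,5-trihydroxy-6-(hydroxymethyl)oxan-2-yl on an oxygen on a saturated carbon, that is, (3,4,5-trihydroxy-6-(hydroxymethyl)oxan-2-yl)oxy to hydroxy, with the rest of the core of compound 1 unchanged.

Going by the values given here, the only measured step, a 1.4-fold lower number from compound 1 to compound 2 (0.13 log units; within the scatter), is acetyl in place of hydrogen on an oxygen on a saturated carbon, within the group that compound 3 lacks. That step is small, but it only alters the group and does not remove it, so it is a weak guide. No measurement in the series shows what removing the whole group does.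

The expected step is a 1.2-fold lower number from compound 1 to compound 3 (0.08 log units; within the scatter), and no change beyond the scatter is expected, though with wide uncertainty. Compound 3 is estimated at 14000 nM, with an expected range of 5000 nM to 40000 nM.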

Compound 3, half-maximal inhibitory concentration: 38900 nM
For compound 3 the middle estimate is 2.8-fold (0.44 log units) below the measured one, within the range that was stated.
By their numbers in this assay, from the lowest: compounds 2 and 1 (each within the scatter of the next); then compound 3.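

In this assay, replacing the 3,4,5-trihydroxy-6-(hydroxymethyl)oxan-2-yl group with hydrogen on the oxygen on a saturated carbon gives a 2.3-fold higher number from compound 1 to compound 3 (0.36 log units; beyond the scatter). Going by these compounds alone, this is the first step to lie beyond the scatter, whereas altering that group by acetylation gave only a 1.4-fold lower number from compound 1 to compound 2 (0.13 log units; within the scatter), so at this position removing the whole group registers where modifying it did not. The loss is modest and does not abolish the read-out, since compound 3 still gives a finite value of 38900 nM, and no available measurement explains the rise in the number at this position.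

From the compounds shown here alone, it remains open whether the step depends on this particular sugar or on having any substituent on this oxygen, which a simple acetyl or methyl group there, or an amino sugar in place of the 3,4,5-trihydroxy-6-(hydroxymethyl)oxan-2-yl group, would help to separate. The compounds shown also share a single core and a single assay, so whether the step carries over to another core or another cell type stays unresolved.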